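A few compounds are considered here, and "the series" means these few. Any claim that something is new, unique, unknown or untested is made for them only; others in the source may bear on it.

Measured so far in this study:

Compound 1 `Nc1nc2c(c(-c3ccco3)cn2[C@@H]2O[C@H](CO)[C@@H](O)[C@H]2O)c(=O)[nH]1`: > 20000 nM, a limit of the assay rather than a number.
Compound 2 `Nc1nc2c(c(-c3cc4ccccc4o3)cn2[C@@H]2O[C@H](CO)[C@@H](O)[C@H]2O)c(=O)[nH]1`: > 20000 nM, again a limit of the assay.
Compound 3 `CNc1ncnc2c1c(-c1cc3ccccc3o1)cn2[C@@H]1O[C@H](CO)[C@@H](O)[C@H]1O`: > 20000 nM, also a limit of the assay.

All three were tested in a functional assay on CEM-DNR-bulk cells (Homo sapiens), read by MTT assay, with a stated time of 72 h; a higher number here means a weaker inhibitor, a lower number a stronger inhibitor. None gave a number: each sits at the limit of > 20000 nM in this assay, at which 3 of the 3 values shown sit. From compound 2 to compound 1 the change is furan-2-yl in place of 1-benzofuran-2-yl on an aromatic carbon and the step is a step that the two limits leave unreadable from compound 2 to compound 1. Compound 4 `CNc1ncnc2c1c(-c1ccco1)cn2[C@@H]1O[C@H](CO)[C@@H](O)[C@H]1O` is not yet measured in this assay. It differs from compound 3 by furan-2-yl in place of 1-benzofuran-2-yl on an aromatic carbon, the same kind of change as from compound 2 to compound 1. How the core of compound 3 differs from that of compound 2 is not broken down here.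

Since compound 3 is itself a limit and the earlier step of this kind stayed unreadable between two limits, compound 4 is expected to stay near the limit as well, so the estimated step is a step that the limit leaves unreadable from compound 3 to compound 4. Compound 4 is therefore estimated at 30000 nM in this assay, with a range from 10000 nM to 100000 nM, and most likely only a limit will be reported.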

Compound 4, half-maximal inhibitory concentration: > 20000 nM
Compound 4: no number, only a limit; the forecaster's own chance of this, stated with the estimate: 80%; the middle value does not contradict the limit.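

Compound 4 gives > 20000 nM, a limit of the assay and not a number. Compound 3 is also only a limit, so no step can be read from compound 3 to compound 4, and compound 4 joins the others: the limit of > 20000 nM in this assay, at which 4 of the 4 values shown sit. The compounds shown leave open how far each lies past that limit, and whether furan-2-yl in place of 1-benzofuran-2-yl changes anything.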